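The source may report more compounds than this note shows. Statements on the series, on what has been measured and on what is new or still open speak of the compounds shown alone.

Compound 3 `COc1ccc(CN2C(=O)C(=O)c3cc(-c4cccc(OC)c4)ccc32)cc1` stands highest of the three numbers in a functional assay on HepG2 cells (Homo sapiens) for antiproliferative activity, read by MTT assay, with a stated time of 48 h (a higher number here means a weaker inhibitor, a lower number a stronger inhibitor), with 1890 nM. Compound 2 `COc1ccc(-c2ccc3c(c2)C(=O)C(=O)N3Cc2cccc(OC)c2)cc1` gives 700 nM, and compound 1 `COc1ccc(-c2ccc3c(c2)C(=O)C(=O)N3Cc2ccc(C)cc2)cc1` gives 330 nM; both lie below compound 3 by more than the scatter. For the measured compounds named here, the only single-place step among the measured compounds is a 2.1-fold higher number from compound 1 to compound 2 (0.33 log units; beyond the scatter), which concerns the group on the saturated chain carbon bound to the amide-type nitrogen, not the aromatic carbon that is changed next. Compound 4 `COc1ccc(CN2C(=O)C(=O)c3cc(-c4ccc(O)cc4)ccc32)cc1` differs from compound 3 by 4-hydroxyphenyl in place of 3-methoxyphenyl on an aromatic carbon. Going by the values given here, no measured step touches that aromatic carbon; compounds 1 and 2 carry another group there but also another group on the nitrogen side, so their lower numbers cannot be assigned to either place. For compound 4 the expected step is a 1.6-fold lower number from compound 3 to compound 4 (0.20 log units; within the scatter), toward a lower number but not clearly beyond the scatter. Compound 4 is expected to give 1200 nM, within 400 nM to 3500 nM.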

Compound 4, half-maximal inhibitory concentration: > 10000 nM
Compound 4: no number, only a limit (the forecaster's own chance of this, stated with the estimate: 5%); middle value at least 8.3-fold (0.92 log units) away from the limit.
By their numbers in this assay, from the lowest: compound 1; then compound 2; then compound 3. At a limit, above all of these: compound 4.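

For the compounds shown here, with the group on the nitrogen held constant, 4-hydroxyphenyl in place of 3-methoxyphenyl on this aromatic carbon gives an at least 5.2-fold higher number from compound 3 to compound 4 (0.72 log units; beyond the scatter) in this assay, the first measured step at this place. The earlier compounds shown here could not separate this carbon from the nitrogen side, whereas this step shows that the aryl group here alone can move the result beyond the scatter. Compound 4 stands at a limit of the assay, not at a number: the limit of > 10000 nM in this assay, at which 1 of the 4 values shown sits.

Still open, on these data alone, is whether the hydroxyl or its place on the phenyl ring carries the step; a 3-hydroxyphenyl or 4-methoxyphenyl group on this carbon, with the nitrogen side of compound 3 kept, would separate the two. Also open, as far as these compounds go, is whether an amine, as 4-aminophenyl, behaves here like 4-hydroxyphenyl.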